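The source may report more compounds than this note shows. Statements on the series, on what has been measured and on what is new or still open speak of the compounds shown alone.

Working notes on the series built around the shared core of compound 1 `COc1ccc(C(=O)/C=C/c2ccc(Br)cc2)c2c1C=CC(C)(C)O2`. In a functional assay on HCT-116 cells (Homo sapiens) for antiproliferative activity, read by MTT assay, with a stated time of 24 h (on this read-out higher numbers stand for weaker inhibition and lower numbers for stronger inhibition), compound 1 gives > 10000 nM, which is a limit of the assay and not a number. Compound 2 `CCN(CC)c1ccc(/C=C/C(=O)c2ccc(OC)c3c2OC(C)(C)C=C3)cc1` carries diethylamino in place of bromo on an aromatic carbon; in this assay compound 2 gives 620 nM, so that an at least 16-fold lower number from compound 1 to compound 2 (1.20 log units; beyond the scatter). Compound 3 `COc1ccc(C(=O)/C=C/c2ccsc2)c2c1C=CC(C)(C)O2` carries thiophen-3-yl in place of 4-bromophenyl on a double-bonded chain carbon bound to a double-bonded chain carbon. In this assay compound 3 gives > 10000 nM, again a limit of the assay. Accordingly a step that the two limits leave unreadable from compound 1 to compound 3. Compound 1 thus stands at the limit of > 10000 nM in this assay, at which 2 of the 3 values shown sit, and only compound 2 sets a number against it.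

Compound 4 `COc1ccc(C(=O)/C=C/c2ccc(Cl)cc2)c2c1C=CC(C)(C)O2` differs from compound 1 by chloro in place of bromo on an aromatic carbon. For the measured compounds named here, of the measured steps from compound 1, an at least 16-fold lower number from compound 1 to compound 2 (1.20 log units; beyond the scatter) brings in a group of a quite different kind, and a step that the two limits leave unreadable from compound 1 to compound 3 gives no size at all; neither exchanges one halogen for another, so no measured step speaks for a change beyond the scatter in this assay. The expected step is therefore a step that the limit leaves unreadable from compound 1 to compound 4, likely unreadable at the limit. Compound 4 is expected to give about 15000 nM in this assay, in a range from 5000 nM to 50000 nM, most probably reported as a limit once more.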

Compound 4, half-maximal inhibitory concentration: > 10000 nM
Compound 4: a limit, no number; the forecaster's own chance of this, stated with the estimate: 80%; the middle value is on the limit's open side.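

In this assay chloro on this aromatic carbon, para to a large group, gives compound 4 a limit of the assay and not a number, so a second halogen at this position joins bromo without a readable value, and the steps from compound 1 and compound 3 to compound 4 cannot be read. With chloro in place of diethylamino at the same position, the series shows an at least 16-fold higher number from compound 2 to compound 4 (1.20 log units; beyond the scatter), so the large gap first seen with bromo now holds for chloro as well. Among the compounds shown, only compound 2 gives a number, and the other three sit together at the limit: the limit of > 10000 nM in this assay, at which 3 of the 4 values shown sit.

On these data alone, how far compound 1, compound 3 and compound 4 lie past the limit stays open, so no order can be drawn among the 4-bromophenyl, 4-chlorophenyl and thiophen-3-yl compounds. Also open, as far as these compounds go, is whether a number at this position is tied to diethylamino itself or would also appear with dimethylamino or a carboxylic acid on the same aromatic carbon.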